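Fluoro to Amino: Expected Cytotoxicity of Compound 4

The compounds below may be only part of what the source reports. "The series", "measured", "known", "first", "only" and "open" are said of these compounds alone.

Three close relatives sharing one core have been tested in an ADME assay on BJ cells (Homo sapiens) for cytotoxicity, with a stated time of 72 h; on this read-out higher numbers stand for an effect only at larger amounts of compound and lower numbers for an effect already at smaller amounts. Compound 2, `Cc1cc(NC(=O)Nc2ccc(F)cc2)c2ccccc2n1`, is the starting point, and in this assay compound 2 gives > 25000 nM, a limit of the assay rather than a number. Compound 1, `Cc1cc(NC(=O)Nc2ccc(F)c(F)c2)c2ccccc2n1`, also stands at a limit, giving > 25000 nM. Within the data shown here, compound 3, `Cc1cc(NC(=O)Nc2ccc(F)cc2F)c2ccccc2n1`, is the only one with a plain number, giving 20000 nM. The first measured step is a step that the two limits leave unreadable from compound 1 to compound 2. The second is an at least 1.2-fold lower number from compound 2 to compound 3 (0.09 log units; that floor lies within the scatter), the only readable one, and it stays inside the scatter. The whole picture is shaped by the limit of > 25000 nM in this assay, at which 2 of the 3 values shown sit, so none of the three compounds harms these cells at the amounts tried.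

Compound 4, `Cc1cc(NC(=O)Nc2ccc(N)cc2)c2ccccc2n1`, differs from compound 2 by amino in place of fluoro on an aromatic carbon. Among the measured compounds shown here, neither measured step bears directly on this exchange, since both concern fluoro and hydrogen only; the one readable step is small. Compound 4 is therefore expected to show no step beyond the scatter, the expected step being a number no higher from compound 2 to compound 4 (the limit leaves the size open). Compound 4 is estimated at 25000 nM, with a range from 8000 nM to 60000 nM, and a reading that is again only a limit is considered likely.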

Compound 4, half-maximal effective concentration: > 25000 nM
Compound 4: a limit, no number; the forecaster's own chance of this, stated with the estimate: 55%; the middle value lies on the limit itself.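

Compound 2 and compound 4 both stand at a limit of the assay rather than at a plain number, so no step between them can be read: the limit of > 25000 nM in this assay, at which 3 of the 4 values shown sit.

The compounds shown leave open whether amino in place of fluoro changes the effect on these cells at all, and at what amount compound 2 or compound 4 would begin to harm them.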